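A few compounds are considered here, and "the series" means these few. Any claim that something is new, unique, unknown or untested is made for them only; others in the source may bear on it.

Measured compounds:
compound 1 `O=C(NO)[C@H]1CCCCN1S(=O)(=O)N1CC=C(c2ccc(Cl)cc2)CC1` — 430 nM; 480 nM (2 entries)
compound 2 `O=C(NO)[C@H]1CCCCN1S(=O)(=O)N1CC=C(c2ccccc2)CC1` — 240 nM

In a functional assay on MONO-MAC-6 cells (Homo sapiens) for inhibition (on this read-out lower numbers stand for stronger inhibition and higher numbers for weaker inhibition), compound 1 gives 430 nM; 480 nM (2 entries); the repeat entries are recorded as the several entries of compound 1 in this assay, 430 nM; 480 nM (2 entries) and agree closely. In this assay, for the measured compounds named here, compound 2 gives 240 nM, the only number it has here, with one further entry that carries no single number. Compound 1 and compound 2 differ only in the para substituent of the phenyl ring, and their values lie close enough that no order between them is asserted.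

Compound 3 `O=C(NO)[C@H]1CCCCN1S(=O)(=O)N1CC=C(c2ccc(F)cc2)CC1` is not yet measured. It differs from compound 2 by fluoro in place of hydrogen on an aromatic carbon. Given that compound 1 and compound 2 sit near each other, the step from compound 2 to compound 3 is expected to be small, likely within the scatter or at most a modest weakening: a 1.3-fold higher number from compound 2 to compound 3 (0.10 log units; within the scatter) is expected. Compound 3 is therefore estimated at 300 nM, with a range from 150 nM to 600 nM.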

Compound 3, half-maximal inhibitory concentration: 300 nM
Beside the measured number, compound 3's estimate shows no gap at the digits printed; low and high end bracket the measured number.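

In this assay, fluoro in place of hydrogen at this position gives a 1.3-fold higher number from compound 2 to compound 3 (0.10 log units; within the scatter), so the change from phenyl to 4-fluorophenyl produces no readable shift. A second halogen can now be set against the first at the same place: compound 3 gives 300 nM and compound 1 gives 430 nM; 480 nM (2 entries), and no order is claimed from these values. The repeat entries at this position agree closely, which gives a direct view of how well the read-out reproduces for one compound: the several entries of compound 1 in this assay, 430 nM; 480 nM (2 entries)

Going by these compounds, whether an amine or a carboxylic acid at this position would move the number beyond the scatter remains open. The compounds shown also say nothing about changes elsewhere on the shared core.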